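The source may hold more compounds than are shown below. What is called first, only, known or untested is meant among the compounds shown, and "the series" means these compounds.

Compound 1 `COc1ccc(-c2nc(/N=C(\N)N(C)C)sc2-c2ccc(OC)cc2)cc1` is the reference point of this set. In a functional assay with Oryctolagus cuniculus as the target (a lower number here means a stronger inhibitor, a higher number a weaker inhibitor), compound 1 gives 37 nM, the lowest of the two numbers shown, and its nearest neighbour is compound 3 `COc1ccc(-c2nc(CNC(=O)NC(C)C)sc2-c2ccc(OC)cc2)cc1`, which gives 42 nM in this assay, so a 1.1-fold higher number from compound 1 to compound 3 (0.06 log units; within the scatter) lies within the scatter. Compound 2 `COc1ccc(-c2nc(CN)sc2-c2ccc(OC)cc2)cc1` is recorded only as a limit, > 100 nM in this assay. This is the limit of > 100 nM in this assay, at which 1 of the 3 values shown sits, and an at least 2.7-fold higher number from compound 1 to compound 2 (0.43 log units; beyond the scatter) tells that cutting the group down to the smaller amine weakened inhibition at least modestly, while an at least 2.3-fold lower number from compound 2 to compound 3 (0.37 log units; beyond the scatter) shows that adding isopropylcarbamoyl on that amine nitrogen recovered it.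

Compound 4 `COc1ccc(-c2nc(C(=O)N(C)C)sc2-c2ccc(OC)cc2)cc1` has not yet been measured. It differs from compound 1 by a group of 5 heavy atoms (3 carbon, 1 nitrogen, 1 oxygen; no ring) in place of a group of 6 heavy atoms (3 carbon, 3 nitrogen; no ring), on an aromatic carbon. Within the data shown here, the change drops the hydrogen-bond donor that compound 1 carries, and the measured steps give no direct precedent for a dimethylcarbamoyl at this position; the loss of the larger group in compound 2 cost potency, whereas the neutral exchange in compound 3 did not. A modest weakening is therefore expected, a 2.2-fold higher number from compound 1 to compound 4 (0.33 log units; beyond the scatter), and compound 4 is estimated at 80 nM in this assay, with a range of 30 nM to 250 nM.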

Compound 4, half-maximal inhibitory concentration: < 100 nM
Compound 4: only a limit was reported (the forecaster's own chance of this, stated with the estimate: 35%); the middle value does not contradict the limit.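

Compound 4 is reported only as a limit, < 100 nM in this assay. The limit still gives a direction: dimethylcarbamoyl, with 0 hydrogen-bond donors, yields a number no higher from compound 2 to compound 4 (the limit leaves the size open). Among these compounds, this shows that a group without a hydrogen-bond donor on this aromatic carbon need not share the loss seen with aminomethyl, which the earlier compounds, all of which carry a donor in this group, could not show.

From the compounds shown here alone, the steps to compound 4 from compound 1 and from compound 3 cannot be read, so it remains open whether dimethylcarbamoyl matches the guanidine-type group of compound 1 or the urea-bearing chain of compound 3. The compounds shown also leave open how a carboxylic acid or an unsubstituted carboxamide on this aromatic carbon would compare.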